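This account rests on a few compounds, and the source may have more. Where it says the series, first, only, none or still open, it means among the compounds named here.

Working notes on the series. Compound 1 `CC(=O)C[C@H]1O[C@@H](On2cc(CN3C(=O)/C(=N\Nc4ccc(C#N)cc4)c4ccccc43)nn2)[C@H](OC(C)=O)[C@@H](OC(C)=O)[C@@H]1OC(C)=O` and compound 2 `CC(=O)C[C@H]1O[C@@H](On2cc(CN3C(=O)/C(=N\Nc4ccc(F)cc4)c4ccccc43)nn2)[C@H](OC(C)=O)[C@@H](OC(C)=O)[C@@H]1OC(C)=O` share one core; compound 3 `N#Cc1ccc(N/N=C2\C(=O)N(Cc3cn(O[C@@H]4O[C@H](CO)[C@H](O)[C@H](O)[C@H]4O)nn3)c3ccccc32)cc1` and the not yet measured compound 4 `O=C1/C(=N\Nc2ccc(F)cc2)c2ccccc2N1Cc1cn(O[C@@H]2O[C@H](CO)[C@H](O)[C@H](O)[C@H]2O)nn1` share another, and the difference between the two cores is not broken down here.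

In an ADME assay on Vero cells (Chlorocebus sabaeus) for cytotoxicity, read by fluorescence and resazurin assay, with a stated time of 3 days (on this read-out higher numbers stand for lower toxicity in this test and lower numbers for higher toxicity in this test), compound 1 gives 75400 nM and compound 2 gives 68700 nM. The change fluoro in place of cyano on an aromatic carbon thus made a 1.1-fold lower number from compound 1 to compound 2 (0.04 log units; within the scatter). In this assay compound 3 gives 93700 nM. Compound 4 carries the same change on the second core, (fluoro in place of cyano on an aromatic carbon), at a place described in the same words, so it counts as the same change. The step from compound 3 to compound 4 is expected to be small, a 1.1-fold lower number from compound 3 to compound 4 (0.04 log units; within the scatter), because a 1.1-fold lower number from compound 1 to compound 2 (0.04 log units; within the scatter) was within the scatter. Compound 4 is therefore estimated at 85000 nM, with a range from 50000 nM to 150000 nM.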

Compound 4, half-maximal cytotoxic concentration: 92100 nM
For compound 4 the middle estimate is 1.1-fold (0.03 log units) below the measured one; low and high end bracket the measured number.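

In this assay fluoro in place of cyano on an aromatic carbon gives a 1.0-fold lower number from compound 3 to compound 4 (0.01 log units; within the scatter). Set beside the earlier step, the change carries from one core to the other without a difference that can be told apart: the same change on two cores in this assay, a 1.1-fold lower number (0.04 log units; within the scatter) from compound 1 to compound 2 and a 1.0-fold lower number (0.01 log units; within the scatter) from compound 3 to compound 4, 1.1-fold (0.03 log units) apart, within the scatter of two such steps. This shows agreement on two cores in this assay only, and since neither step leaves the scatter, it does not show that a change with a larger step would carry over in the same way, nor does it speak to any other read-out.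

The compounds shown leave open whether a different group in the same place, such as an amine or a carboxylic acid, would move the number beyond the scatter. As far as these compounds go, how the two cores themselves compare also stays open.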